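A few compounds are considered here, and "the series" means these few. Any claim that something is new, unique, unknown or untested is made for them only; others in the source may bear on it.

Measured compounds:
- compound 1 `C[Si](C)(C)CCOCn1c(CC(O)(CO)CO)cc(=O)[nH]c1=O`: > 100000 nM
- compound 2 `C[Si](C)(C)CCOCn1c(CC(O)COCc2ccccc2)cc(=O)[nH]c1=O`: > 100000 nM

Both values come from a functional assay on MIA PaCa-2 cells (Homo sapiens) for antiproliferative activity, read by MTT assay, with a stated time of 72 h; a higher number here means a weaker inhibitor, a lower number a stronger inhibitor. For compound 1 the value > 100000 nM is a limit of the assay, not a number. For compound 2 the value > 100000 nM is likewise a limit of the assay and not a number. Within the data shown here, compound 2 therefore stands at the same limit as every value shown (the limit of > 100000 nM in this assay, at which 2 of the 2 values shown sit), so no step between measured compounds exists and no order between compound 1 and compound 2 can be stated.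

Compound 3 `C[Si](C)(C)CCOCn1c(CC(O)CO)cc(=O)[nH]c1=O` has not yet been measured in this assay. It differs from compound 2 by hydrogen in place of benzyl on an oxygen on a saturated carbon. With compound 2 sitting at a limit > 100000 nM, the expected step that the limit leaves unreadable from compound 2 to compound 3 cannot be sized from the data and is expected to show no movement beyond the scatter that the assay could resolve. For compound 3 the estimate in this assay is 150000 nM, with a range from 30000 nM to 1000000 nM, and a limit rather than a number is the expected outcome.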

Compound 3, half-maximal inhibitory concentration: > 100000 nM
Compound 3: only a limit was reported; the forecaster's own chance of this, stated with the estimate: 85%; the middle value is on the limit's open side.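

Compound 3 gives > 100000 nM in this assay and this is a limit of the assay, not a number. Among these compounds, no step from compound 1 or compound 2 to compound 3 can be read, since all three compounds stand at one limit: the limit of > 100000 nM in this assay, at which 3 of the 3 values shown sit.

The compounds shown leave open how replacing benzyl or hydroxymethyl with hydrogen alters antiproliferative activity in this assay.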